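The source may hold more compounds than are shown below. What is called first, only, known or untested is meant among the compounds shown, and "the series" means these compounds.

Measured so far in an ADME assay on RAW264.7 cells (Mus musculus) for cytotoxicity, read by MTT assay, with a stated time of 72 h, tested at 50 uM; on this read-out higher numbers stand for more inhibition at the one concentration tested (going by the name of the read-out) and lower numbers for less inhibition:
- compound 1 `CCOC(=O)c1sc(-c2ccccc2)nc1N1CCC(NCc2ccc(OC)cc2)CC1` gives 8.4%
- compound 2 `CCOC(=O)c1sc(-c2ccccc2)nc1N1CCC(NCc2ccc(OCc3ccccc3)cc2)CC1` gives 18.4%
- compound 3 `CCOC(=O)c1sc(-c2ccncc2)nc1N1CCC(NCc2ccc(OC)cc2)CC1` gives 16.1%

Compound 2 differs from compound 1 by phenyl in place of hydrogen on a saturated chain carbon bound to an oxygen on an aromatic ring. The step is a number 10 percentage points higher from compound 1 to compound 2 (within the scatter). Compound 3 differs from compound 1 in the core by pyridin-4-yl in place of phenyl on an aromatic carbon, and that step is a number 7.7 percentage points higher from compound 1 to compound 3 (within the scatter). Compound 2 and compound 3 lie within the scatter of one another.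

Compound 4 `CCOC(=O)c1sc(-c2ccncc2)nc1N1CCC(NCc2ccc(OCc3ccccc3)cc2)CC1` is not yet measured in this assay. For the measured compounds named here, it differs from compound 3 by phenyl in place of hydrogen on a saturated chain carbon bound to an oxygen on an aromatic ring, which is the same change as the one from compound 1 to compound 2, made at the same place on the core of compound 3. Going by the values given here, the only measured example of this change is the step from compound 1 to compound 2, which stays within the scatter, so the expected step from compound 3 to compound 4 is a number 7.9 percentage points higher from compound 3 to compound 4 (within the scatter), resting on a number 10 percentage points higher from compound 1 to compound 2 (within the scatter). Compound 4 is therefore expected to give 24%, with a likely range of 12% to 38%, because compound 3 starts from 16.1%.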

Compound 4, a percentage reported as inhibition, at one concentration (the size of the read-out at that concentration, not a potency): 8.04%
For compound 4 the middle estimate is 16 percentage points above the measured one, outside the stated range (below it).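

In this assay, methoxy to benzyloxy on the core carrying pyridin-4-yl gives a number 8.1 percentage points lower from compound 3 to compound 4 (within the scatter), and this change does not carry over from the core of compound 1 to the core of compound 3: the same change on two cores in this assay, a number 10 percentage points higher (within the scatter) from compound 1 to compound 2 and a number 8.1 percentage points lower (within the scatter) from compound 3 to compound 4, 18.1 percentage points apart, beyond the scatter of two such steps. Read on the benzyloxy compounds, pyridin-4-yl in place of phenyl gives a number 10.4 percentage points lower from compound 2 to compound 4 (beyond the scatter), and this change likewise depends on its partner group: the same change on two cores in this assay, a number 7.7 percentage points higher (within the scatter) from compound 1 to compound 3 and a number 10.4 percentage points lower (beyond the scatter) from compound 2 to compound 4, 18.1 percentage points apart, beyond the scatter of two such steps. Both gaps rest on the same four values and count as one observation, which shows that the two changes do not add in this set but does not show why, or whether the same holds on any other core.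

Still open, going by these compounds, is whether this behaviour persists with an ethoxy group or a longer alkoxy chain in place of benzyloxy, or with pyridin-3-yl in place of pyridin-4-yl. Also open, on these data alone, is whether it survives replacing the ethyl ester of the shared core with a carboxylic acid or an amide.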